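Working notes: isopropyl in place of cyano

The source may hold more compounds than are shown below. What is called first, only, known or untested is meant among the compounds shown, and "the series" means these compounds.

Values in an in vitro ADME assay on microsomes from liver (Mus musculus) for pharmacokinetics, read by LC-MS, with a stated time of 10 min, tested at 1 uM (on this read-out higher numbers stand for fast clearance and lower numbers for slow clearance), are:
- compound 1 `CN1C[C@H](C(=O)Nc2ccccc2)[C@@H](c2ccc(/C=C/C(=O)Nc3ccccc3N)cc2)C1` gives 67 mL/min/kg here
- compound 2 `CN1C[C@H](C(=O)Nc2ccc(F)cc2)[C@@H](c2ccc(/C=C/C(=O)Nc3ccccc3N)cc2)C1` gives 34 mL/min/kg here
- compound 3 `CN1C[C@H](C(=O)Nc2ccc(C#N)cc2)[C@@H](c2ccc(/C=C/C(=O)Nc3ccccc3N)cc2)C1` gives 35 mL/min/kg here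

Compound 3 at 35 mL/min/kg stands within the scatter of both other compounds, so no order among the three can be read. Compound 4 `CC(C)c1ccc(NC(=O)[C@H]2CN(C)C[C@@H]2c2ccc(/C=C/C(=O)Nc3ccccc3N)cc2)cc1` carries isopropyl in place of cyano on an aromatic carbon, para to a large group (isopropyl in place of cyano on an aromatic carbon). Going by the values given here, three measured steps bear on this change: a 2.0-fold lower number from compound 1 to compound 2 (0.29 log units; within the scatter) with fluoro in place of hydrogen, a 1.9-fold lower number from compound 1 to compound 3 (0.28 log units; within the scatter) with cyano in place of hydrogen and a 1.0-fold higher number from compound 2 to compound 3 (0.01 log units; within the scatter) with cyano in place of fluoro. All lie within the scatter, but none involves isopropyl, so the guidance is indirect. Compound 1 at 67 mL/min/kg has neither fluoro nor cyano at this place and is taken as the closest guide, which suggests a small upward lean. The estimated change is a 1.4-fold higher number from compound 3 to compound 4 (0.15 log units; within the scatter) in this assay and is expected to stay within the scatter. For compound 4 the expected value is 50 mL/min/kg with an estimated range from 25 mL/min/kg to 100 mL/min/kg in this read-out.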

Compound 4, clearance: 54 mL/min/kg
Beside the measured number, compound 4's estimate is 1.1-fold (0.03 log units) below it; measured number inside the range.
By their numbers in this assay, from the lowest: compounds 2, 3, 4 and 1 (each within the scatter of the next).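

In this assay isopropyl, on an aromatic carbon para to a large group, stays within the scatter of cyano (a 1.5-fold higher number from compound 3 to compound 4 (0.19 log units; within the scatter)), of fluoro (a 1.6-fold higher number from compound 2 to compound 4 (0.20 log units; within the scatter)) and of hydrogen (a 1.2-fold lower number from compound 1 to compound 4 (0.09 log units; within the scatter)). A group of carbon only thus joins hydrogen, fluoro and cyano at this place with no step beyond the scatter, so the four groups cannot be put in any order on this read-out. Nothing measured here offers an explanation for these numbers.

Still open, as far as these compounds go, is whether a carboxylic acid, an amine or a longer chain at this place would give a step beyond the scatter. Also open, from the compounds shown here alone, is whether changes elsewhere on the shared core would move clearance more than changes at this place.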